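The compounds below may be only part of what the source reports. "The series", "measured", "known", "first", "only" and "open" are said of these compounds alone.

The measured compounds in an assay for inhibition of Alpha amylase (Homo sapiens), with a stated time of 30 min; a lower number here means a stronger inhibitor, a higher number a weaker inhibitor: compound 1, `CCOC(=O)c1c(-c2ccccc2)nn(-c2ccccc2)c1COc1ccc(C=O)cc1OC`, gives 60 ug/mL; compound 2, `CCOC(=O)c1c(-c2ccccc2)nn(-c2ccccc2)c1Cn1c(S)nc2ccccc21`, gives 40 ug/mL; compound 3, `CCOC(=O)c1c(-c2ccccc2)nn(-c2ccccc2)c1COCc1ccccc1`, gives 45 ug/mL.

Compound 2 has the smallest of the three numbers, yet the step of a 1.5-fold lower number from compound 1 to compound 2 (0.18 log units; within the scatter) and the step of a 1.1-fold higher number from compound 2 to compound 3 (0.05 log units; within the scatter) are both within the scatter, so the three compounds cannot be told apart on these data. Compound 4, `CCOC(=O)c1c(-c2ccccc2)nn(-c2ccccc2)c1Cn1c(S)nc2ccc(OC(F)F)cc21`, is not yet measured; it differs from compound 2 by difluoromethoxy in place of hydrogen on an aromatic carbon, on the six-membered ring that is part of a fused or bridged system of two rings. Going by the values given here, no measured step touches that ring: the steps of a 1.5-fold lower number from compound 1 to compound 2 (0.18 log units; within the scatter), a 1.3-fold lower number from compound 1 to compound 3 (0.12 log units; within the scatter) and a 1.1-fold higher number from compound 2 to compound 3 (0.05 log units; within the scatter) all exchange the group on the saturated chain carbon bound to the shared core, and every one of them stayed within the scatter. They give no ground to expect a step beyond the scatter in this assay in either direction. Compound 4 is therefore estimated at 35 ug/mL, with a range from 18 ug/mL to 70 ug/mL. The expected step of a 1.1-fold lower number from compound 2 to compound 4 (0.06 log units; within the scatter) is small, and its direction is uncertain.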

Compound 4, half-maximal inhibitory concentration: 10 ug/mL
Beside the measured number, compound 4's estimate is 3.5-fold (0.54 log units) above it; measured number below the stated range.
By their numbers in this assay, from the lowest: compound 4; then compounds 2, 3 and 1 (each within the scatter of the next).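

In this assay, going by these compounds alone, the step of a 4.0-fold lower number from compound 2 to compound 4 (0.60 log units; beyond the scatter) is the first in this set to lie beyond the scatter, and it follows a single change: difluoromethoxy in place of hydrogen on an aromatic carbon of the six-membered ring in the fused system. The earlier steps all exchanged the group on the saturated chain carbon bound to the shared core and stayed within the scatter, so this ring position is the only place shown where a change moves the number measurably. Nothing measured here accounts for why this change has this effect.

On these data alone, it remains open whether a methoxy group, a chlorine or a trifluoromethyl group at the same carbon would give a similar step. As far as these compounds go, it is also open whether difluoromethoxy would give the same step on another carbon of that ring.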